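A few compounds are considered here, and "the series" means these few. Any claim that something is new, unique, unknown or untested is made for them only; others in the source may bear on it.

Compound 1 `CC(=O)Nc1cccc(-c2ccc(C(=O)N(Cc3cccc(OCCCCCC(=O)O)c3)C(C)C)cc2)c1` gives only a limit in an ADME assay on HEK293 cells (Homo sapiens) for cytotoxicity, read by CellTiter-Glo and resazurin assay, with a stated time of 72 h (a higher number here means that more compound is needed for the effect, a lower number that less compound is needed), namely > 26000 nM.
Compound 2 `CC(C)N(Cc1cccc(OCCCCCC(=O)O)c1)C(=O)c1ccc(-c2ccc3[nH]ccc3c2)cc1` likewise gives only a limit in this assay, namely > 26000 nM.

Both values are limits of the assay, not numbers. Compound 2 therefore stands at the ceiling of what this assay can report, and it is not alone there. Among the compounds with values here, the single measured step, a step that the two limits leave unreadable from compound 1 to compound 2, cannot be sized because of the limit of > 26000 nM in this assay, at which 2 of the 2 values shown sit.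

Compound 3 `CC(C)N(Cc1cccc(OCCCCCC(=O)O)c1)C(=O)c1ccc(-c2ccc3cc[nH]c3c2)cc1` is the next compound, and it differs from compound 2 by 1H-indol-6-yl in place of 1H-indol-5-yl on an aromatic carbon. Within the data shown here, no measured step speaks to this rearrangement of the same atoms, so there is no readable precedent either way. With both measured compounds resting at the limit, the plain expectation is that compound 3 also produces no number in this assay. The estimate for compound 3 is 30000 nM, with a range from 15000 nM to 80000 nM, which means the expected step that the limit leaves unreadable from compound 2 to compound 3 is nothing beyond the usual scatter.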

Compound 3, half-maximal effective concentration: > 26000 nM
Compound 3 ended at the assay's limit; the forecaster's own chance of this, stated with the estimate: 85%; the middle value lies beyond the limit too.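

Within the data shown here, no step between compound 1, compound 2 and compound 3 can be read, since each gives only a limit of the assay and not a number: the limit of > 26000 nM in this assay, at which 3 of the 3 values shown sit. The compounds shown leave open at what concentration, if any, each would show an effect in this assay.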